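Methyl on the anilino ring: cytotoxicity notes

The compounds below may be only part of what the source reports. "The series", "measured", "known", "first", "only" and "open" are said of these compounds alone.

Compound 1, `Cc1ccccc1Nc1nc(N)nc(CSc2nnc(-c3ccccc3)n2/N=C/c2ccc(Br)cc2)n1`: in an ADME assay on Vero cells (Chlorocebus sabaeus) for cytotoxicity, read by resazurin assay, with a stated time of 3 days (a higher number here means that more compound is tolerated, a lower number that less compound is tolerated), compound 1 gives 1500 ug/mL.
Compound 2, `Cc1ccc(Nc2nc(N)nc(CSc3nc4cc(C)ccc4[nH]3)n2)cc1`: in this assay compound 2 gives "not determined" (no result reported), that is, no reported result.
Compound 3, `Nc1nc(CSc2nc3ccccc3[nH]2)nc(Nc2ccccc2)n1`: in this assay compound 3 gives "not determined" (no result reported), that is, no reported result.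

Within the data shown here, compound 3 stands without a number in this assay, and compound 2 is in the same position, so compound 1 supplies the only measured value in the set. Compound 4, `Cc1ccccc1Nc1nc(N)nc(CSc2nc3ccccc3[nH]2)n1`, remains to be measured. The change from compound 3 to compound 4 is methyl in place of hydrogen on an aromatic carbon. Among the measured compounds shown here, no step between measured compounds covers this change, so its size cannot be read from the data. For the measured compounds named here, a change of this small size is expected to give no step in this assay beyond the usual scatter, in either direction. Compound 4 carries the same (2-methylphenyl)amino group as compound 1, and in this assay compound 1 is tolerated at 1500 ug/mL, so a similarly high tolerance is expected here. Compound 4 is expected to give about 1000 ug/mL in this assay, with a range from 300 ug/mL to 3000 ug/mL.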

Compound 4, half-maximal cytotoxic concentration: > 2000 ug/mL
Compound 4 ended at the assay's limit; the forecaster's own chance of this, stated with the estimate: 30%; middle value at least 2.0-fold (0.30 log units) from the limit.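

No step can be read from the results for compound 3 and compound 4. In this assay compound 4 gives > 2000 ug/mL, which is a limit of the assay and not a number. The compounds shown leave open how far phenyl to 2-methylphenyl shifts tolerance.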